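A few compounds are considered here, and "the series" means these few. Any claim that something is new, unique, unknown or untested is made for them only; others in the source may bear on it.

Working notes on the series, all read in a physicochemical assay for acid dissociation. Compound 1 `O=S(=O)(Nc1ccc(Cl)cc1)c1ccccc1` gives 8.75. Compound 2 `O=S(=O)(Nc1ccc(F)cc1)c1ccccc1` gives 8.85. Compound 3 `Cc1ccc(NS(=O)(=O)c2ccc(F)cc2)cc1` gives 9.23, the highest of the three numbers, beyond the scatter from both others. The change from compound 2 to compound 1 is chloro in place of fluoro on an aromatic carbon; it produced a number 0.10 log units lower from compound 2 to compound 1 (within the scatter). Compound 4 `Cc1ccc(NS(=O)(=O)c2ccc(Cl)cc2)cc1` awaits measurement. Its difference from compound 3 is chloro in place of fluoro on an aromatic carbon, the same change at the same place as between compound 2 and compound 1. How the core of compound 3 differs from the core of compound 2 is not broken down here. Among the measured compounds shown here, for compound 4 the expected step is a number 0.10 log units lower from compound 3 to compound 4 (within the scatter), because a number 0.10 log units lower from compound 2 to compound 1 (within the scatter) is the only earlier instance of this change and lay within the scatter. Compound 4 is accordingly estimated at 9.13, with a likely range from 8.85 to 9.4.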

Compound 4, acid dissociation constant: 8.78
Beside the measured number, compound 4's estimate is 0.35 log units above it; the measured number lies below the stated range.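

In this assay chloro in place of fluoro on an aromatic carbon gives a number 0.45 log units lower from compound 3 to compound 4 (beyond the scatter) on one core and a number 0.10 log units lower from compound 2 to compound 1 (within the scatter) on the other, so the step read on one core did not carry over in size to the other. These two instances show that the size of this step can depend on the core, but they give no rule for how it does, nor for any core beyond these two. Nothing at hand accounts for the difference between the two steps.

The compounds shown leave open how a bromo, a methoxy or a nitrile in the same place would read on either core. As far as these compounds go, whether the step seen on the core of compound 3 recurs on further cores also stays open.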